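This account rests on a few compounds, and the source may have more. Where it says the series, first, only, none or still open, it means among the compounds named here.

Compound 1 `COc1ccc(CN(C(=O)CSc2nc3ccccc3s2)c2cc(OC)c(OC)c(OC)c2)cc1N=[N+]=[N-]` and compound 2 `COc1ccc(CN(C(=O)CSc2nc3ccccc3s2)c2cc(OC)c(OC)c(OC)c2)cc1[N+](=O)[O-]` share one core and differ only in the group carried on the aromatic carbon that sits ortho to the methoxy group. In a functional assay on HCT-116 cells (Homo sapiens) for antiproliferative activity, read by MTT assay, with a stated time of 48 h (on this read-out higher numbers stand for weaker inhibition and lower numbers for stronger inhibition), compound 1 gives 2860 nM, and compound 2 gives 1280 nM, a change described by a 2.2-fold lower number from compound 1 to compound 2 (0.35 log units; beyond the scatter). For the measured compounds named here, compound 2 therefore holds the lowest of the two numbers measured so far, with compound 1 as its only neighbour.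

Compound 3 `COc1ccc(CN(C(=O)CSc2nc3ccccc3s2)c2cc(OC)c(OC)c(OC)c2)cc1N` is the next member, obtained from compound 2 by amino in place of nitro on an aromatic carbon. Going by the values given here, the single measured step bears on it only loosely: it shows that exchanging one group at this position for another moved this assay by a modest amount, but neither compound 1 nor compound 2 carries an amino group, so no step in the data tracks this exact change. Among the compounds with values here, with the size of the one known step as the only guide, a shift of about that magnitude or less is expected in either direction, most likely a somewhat higher number. Compound 3 is estimated at 2000 nM, within 700 nM to 6000 nM, meaning an expected step of a 1.6-fold higher number from compound 2 to compound 3 (0.19 log units; within the scatter).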

Compound 3, half-maximal inhibitory concentration: 491 nM
For compound 3 the middle estimate is 4.1-fold (0.61 log units) above the measured one; measured number outside the range, below it.
By their numbers in this assay, from the lowest: compound 3; then compound 2; then compound 1.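

At this carbon, ortho to a methoxy group, the change from nitro to amino in this assay gives a 2.6-fold lower number from compound 2 to compound 3 (0.42 log units; beyond the scatter) and so goes further than the earlier exchange of azido for nitro, while the change from azido to amino gives a 5.8-fold lower number from compound 1 to compound 3 (0.77 log units; beyond the scatter) as the largest step among the three compounds. The position therefore responds to more than one exchange, and the three groups fall into a clear order, with amino giving the lowest number, then nitro, then azido. Amino replaces the 3 heavy atoms of nitro with 1 heavy atom and carries 1 hydrogen-bond donor where nitro has 0, but no measurement here separates these differences or explains the order.

The compounds shown leave open whether the amino hydrogens are needed, since no methylamino, dimethylamino or acetamido group stands at this carbon among them. They also leave open how a hydroxyl group or a simple hydrogen at the same carbon would compare with amino in this assay on the shared core.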